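The source may hold more compounds than are shown below. What is called first, only, known or untested is meant among the compounds shown, and "the series" means these compounds.

Compound 1 `O=c1nc(N2CCN(NCC3CCCCC3)CC2)sc2c([N+](=O)[O-])cc(C(F)(F)F)cc12` gives 29.3 ug/mL in an ADME assay on Vero cells (Chlorocebus sabaeus) for cytotoxicity, read by MTT assay, with a stated time of 72 h; on this read-out lower numbers stand for higher toxicity in this test and higher numbers for lower toxicity in this test. Compound 2 `CON=C1CCC(N(C)N2CCN(c3nc(=O)c4cc(C(F)(F)F)cc([N+](=O)[O-])c4s3)CC2)CC1` gives > 64 ug/mL in this assay, a limit of the assay and not a number. Compound 3 `O=c1nc(N2CCN(NCc3ccc(F)cc3)CC2)sc2c([N+](=O)[O-])cc(C(F)(F)F)cc12` gives > 64 ug/mL in this assay, again a limit.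

Compound 3 thus stands at the limit of > 64 ug/mL in this assay, at which 2 of the 3 values shown sit, with no number of its own. Compound 4 `Cc1ccc(CNN2CCN(c3nc(=O)c4cc(C(F)(F)F)cc([N+](=O)[O-])c4s3)CC2)cc1` differs from it by methyl in place of fluoro on an aromatic carbon. Within the data shown here, no measured step alters this position on the ring; the nearest is an at least 2.1-fold higher number from compound 1 to compound 3 (0.33 log units; beyond the scatter), which brought in the 4-fluorophenyl, and a step that the two limits leave unreadable from compound 2 to compound 3. Both end at the limit, so they set no size for a further change at the aromatic carbon. No step beyond the scatter is expected here, and compound 4 is expected to give 70 ug/mL (range 30 ug/mL to 150 ug/mL), meaning a step that the limit leaves unreadable from compound 3 to compound 4.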

Compound 4, half-maximal cytotoxic concentration: > 64 ug/mL
Compound 4: no number, only a limit; the forecaster's own chance of this, stated with the estimate: 65%; the middle value lies beyond the limit too.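

In this assay compound 4 gives > 64 ug/mL, a limit of the assay and not a number. With an at least 2.1-fold higher number from compound 1 to compound 4 (0.33 log units; beyond the scatter), the step seen with 4-fluorophenyl also appears with 4-methylphenyl, so it does not depend on fluoro at this aromatic carbon. The steps from compound 3 to compound 4 and from compound 2 to compound 4 cannot be read, and the values gather at one limit: the limit of > 64 ug/mL in this assay, at which 3 of the 4 values shown sit.

From the compounds shown here alone, whether fluoro and methyl differ at all on this read-out stays open, as neither compound 3 nor compound 4 has a number of its own. Going by these compounds, how an amine or a carboxylic acid at this aromatic carbon would read in this assay also stays open.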